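The source may hold more compounds than are shown below. What is called first, only, known or untested is meant among the compounds shown, and "the series" means these compounds.

Measured compounds:
compound 1, `CC1=C(C(=O)OC(C)(C)C)C(c2cccs2)NC(=O)N1`: 7%
compound 2, `CC1=C(C(=O)OCc2ccccc2)C(c2cccs2)NC(=O)N1`: 8%

In an assay on membranes from HeLa cells for displacement of a labelled ligand from adenosine receptor A3 (Homo sapiens), read by scintillation counting, with a stated time of 180 min, tested at 1 uM (on this read-out higher numbers stand for more inhibition at the one concentration tested (going by the name of the read-out) and lower numbers for less inhibition), compound 1 gives 7%, the lower of the two numbers shown. Going by the values given here, compound 2 gives 8% in this assay, and the one measured step, a number 1 percentage points higher from compound 1 to compound 2 (within the scatter), came from swapping benzyl for tert-butyl on an oxygen next to a carbonyl group.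

Compound 3, `CCN(CC)C(=O)C1=C(C)NC(=O)NC1c1cccs1`, has not yet been measured in this assay. It differs from compound 1 as follows: diethylamino in place of tert-butoxy on a carbonyl carbon. The measured step changed only the group on the oxygen, whereas here the whole tert-butoxy group leaves and diethylamino enters at the carbonyl carbon, so that step bears on the new change only loosely. Among the compounds with values here, with both measured compounds giving small numbers and the one known step staying within the scatter, the step from compound 1 to compound 3 is expected to be a number 1 percentage points higher from compound 1 to compound 3 (within the scatter), none beyond the scatter. Compound 3 is therefore estimated at 8%, with a range from 0% to 22%.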

Compound 3, a percentage reported as inhibition, at one concentration (the size of the read-out at that concentration, not a potency): 31%
Estimate against measurement, compound 3: 23 percentage points below, outside the stated range (above it).
By their numbers in this assay, from the lowest: compounds 1 and 2 (each within the scatter of the next); then compound 3.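

In this assay, replacing tert-butoxy with diethylamino on a carbonyl carbon gives a number 24 percentage points higher from compound 1 to compound 3 (beyond the scatter), so this position can respond to a change, which the step of a number 1 percentage points higher from compound 1 to compound 2 (within the scatter) did not show when only the group on the oxygen was altered. Both groups hold 5 heavy atoms, so the rise comes without any change in that count, and the atom joined to the carbonyl carbon is nitrogen rather than oxygen. Nothing available explains why the number rises.

From the compounds shown here alone, it remains open whether the rise belongs to diethylamino alone or would also appear with another amine, such as dimethylamino or piperidine, or with a carboxylic acid at this carbon. Going by these compounds, a reading at a single concentration also gives no potency, so how tightly compound 3 binds remains unknown.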